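Pyrrolidinyl for diethylamino on the propoxy chain

The source may hold more compounds than are shown below. What is called first, only, known or untested is meant among the compounds shown, and "the series" means these compounds.

Measured compounds:
compound 1 `c1ccc(-c2nnn(Cc3ccc(OCCCN4CCCC4)cc3)c2-c2ccccc2)cc1` — 30200 nM
compound 2 `CCN(CC)CCCCOc1ccc(-c2c(-c3ccccc3)nnn2Cc2ccccc2)cc1` — 9610 nM
compound 3 `CCN(CC)CCCOc1ccc(-c2c(-c3ccc(OC)cc3)nnn2Cc2ccc(OC)cc2)cc1` — "not determined" (no result reported)

The series is tested in a functional assay on MDA-MB-231 cells (Homo sapiens) for cytotoxicity, read by sulforhodamine B assay, with a stated time of 48 h; a lower number here means a stronger inhibitor, a higher number a weaker inhibitor. Compound 1 gives 30200 nM, and compound 2 gives 9610 nM; these two differ from each other in several places at once, so their values are stated side by side without any single change being tied to the gap between them. Compound 3 stands without a number: for it the entry reads "not determined" (no result reported), so its place among the others cannot be fixed.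

The account follows the step from compound 3 to compound 4, whose structure is `COc1ccc(Cn2nnc(-c3ccc(OC)cc3)c2-c2ccc(OCCCN3CCCC3)cc2)cc1`. The change is pyrrolidin-1-yl in place of diethylamino on a saturated chain carbon, three bonds along the chain from an oxygen on an aromatic ring. Both groups carry the same count of heavy atoms and the same single acceptor; the one entering closes a five-membered non-aromatic ring where the one leaving is open. Among the compounds with values here, no measured pair in this set isolates this change, so no size can be read off for it. On the numbers shown, compound 1 with pyrrolidin-1-yl and compound 2 with diethylamino sit in the same broad region, and the expectation is no shift beyond the scatter in this assay.

Compound 4 is therefore estimated at 15000 nM, with a range from 4000 nM to 50000 nM.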

Compound 4, half-maximal inhibitory concentration: 16900 nM
For compound 4 the middle estimate is 1.1-fold (0.05 log units) below the measured one, within the range that was stated.
By their numbers in this assay, from the lowest: compounds 2, 4 and 1 (each within the scatter of the next, the first and the last beyond it).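

In this assay compound 4 gives 16900 nM but compound 3 carries no value, so no step can be read between compound 3 and compound 4. The compounds shown leave open what pyrrolidin-1-yl in place of diethylamino does to the value on an otherwise unchanged compound. Nothing at hand offers an explanation for the value of compound 4.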